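Swapping Fluoro for Methyl: What Cytotoxicity to Expect

This account rests on a few compounds, and the source may have more. Where it says the series, first, only, none or still open, it means among the compounds named here.

Compound 1 `O=C(/C=C/c1cccc(Cl)c1)c1ccccc1O` and compound 2 `O=C(/C=C/c1cccc(F)c1)c1ccccc1O` differ in one place. In a functional assay on HCT-116 cells (Homo sapiens) for cytotoxicity, read by MTT assay, with a stated time of 48 h, tested at 15 uM (on this read-out higher numbers stand for a weaker effect at the one concentration tested and lower numbers for a stronger effect), compound 1 gives 37.5%, and compound 2 gives 45.3%. The step of a number 7.8 percentage points higher from compound 1 to compound 2 (within the scatter) stays within the scatter, so compound 2 shows the higher of the two numbers without a real difference between them. Compound 3 `Cc1cccc(/C=C/C(=O)c2ccccc2O)c1` is not yet measured; it differs from compound 2 by methyl in place of fluoro on an aromatic carbon. Among the compounds with values here, only the step from compound 1 to compound 2 bears on this change, and it was small, so no step beyond the scatter is expected in this assay. Compound 3 is therefore expected to give about 42%, between 28% and 58%. The expected step is a number 3.3 percentage points lower from compound 2 to compound 3 (within the scatter).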

Compound 3, a percentage reported as activity, at one concentration (the size of the read-out at that concentration, not a potency): 85.9%
Estimate against measurement, compound 3: 43.9 percentage points below; the whole stated range lies below it.
By their numbers in this assay, from the lowest: compounds 1 and 2 (each within the scatter of the next); then compound 3.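

At this aromatic carbon, the swap to methyl matters far more than the swap between the two halogens did: in this assay, where a higher number means a weaker effect, the change is a number 40.6 percentage points higher from compound 2 to compound 3 (beyond the scatter) and, against the chloro compound, a number 48.4 percentage points higher from compound 1 to compound 3 (beyond the scatter) on the same read-out. The close numbers for chloro and fluoro therefore did not mean that this position tolerates any small group. No measurement here accounts for the weaker effect of methyl. Going by these compounds, whether a hydroxyl, an amine or a methoxy group at this carbon would behave like the halogens or like methyl stays open.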